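The source may report more compounds than this note shows. Statements on the series, on what has been measured and on what is new or still open speak of the compounds shown alone.

Measured in a functional assay on MCF7 cells (Homo sapiens) for cytotoxicity, read by MTT assay, with a stated time of 72 h; a higher number here means a weaker inhibitor, a lower number a stronger inhibitor:
compound 1 `CNC(=O)c1cc(Oc2ccc(C(=O)/C=C/c3cccc(Br)c3)cc2)ccn1`: 10400 nM
compound 2 `CNC(=O)c1cc(Oc2ccc(C(=O)/C=C/c3ccc(OC)c(OC)c3OC)cc2)ccn1`: 2910 nM
compound 3 `CNC(=O)c1cc(Oc2ccc(C(=O)/C=C/c3ccc(Br)cc3)cc2)ccn1`: > 50000 nM (a limit)

Of the two true numbers, compound 1 at 10400 nM is the higher, and compound 2 reads lower at 2910 nM. Compound 3 gives only a limit, > 50000 nM.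

Next in the series is compound 4 `CNC(=O)c1cc(Oc2ccc(C(=O)/C=C/c3ccc(F)cc3Cl)cc2)ccn1`, which differs from compound 1 as follows: 2-chloro-4-fluorophenyl in place of 3-bromophenyl on a double-bonded chain carbon bound to a double-bonded chain carbon. The 2-chloro-4-fluorophenyl group replaces 3-bromophenyl on a double-bonded chain carbon bound to a double-bonded chain carbon.

For the measured compounds named here, one measured step bears on this change, with 4-bromophenyl in place of 3-bromophenyl: an at least 4.8-fold higher number from compound 1 to compound 3 (0.68 log units; beyond the scatter). That step is only a partial guide, since the group in compound 4 is not the 4-bromophenyl group of compound 3. A move toward a higher number in this assay is expected, smaller than that step and possibly no larger than the scatter.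

The expected change is a 1.4-fold higher number from compound 1 to compound 4 (0.16 log units; within the scatter).

Compound 4 is estimated at 15000 nM, with an expected range of 4000 nM to 50000 nM.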

Compound 4, half-maximal inhibitory concentration: 21100 nM
Compound 4: middle estimate off by 1.4-fold (0.15 log units), on the low side; the measured number falls inside the stated range.
By their numbers in this assay, from the lowest: compound 2; then compound 1; then compound 4. At a limit, above all of these: compound 3.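

In this assay, replacing the single bromine with two different halogens still costs potency: a 2.0-fold higher number from compound 1 to compound 4 (0.31 log units; beyond the scatter). Against the 4-bromophenyl group, 2-chloro-4-fluorophenyl recovers a measurable number: an at least 2.3-fold lower number from compound 3 to compound 4 (0.37 log units; beyond the scatter). Among the compounds shown, a halogen on the phenyl group bound to the double-bonded chain carbon therefore does not by itself send the result to the top of the range, with compound 4 reading a true number and compound 3 not.

Compound 3 gives only a limit: the limit of > 50000 nM in this assay, at which 1 of the 4 values shown sits.

Which halogen of the 2-chloro-4-fluorophenyl group carries the step stays open, and 2-chlorophenyl and 4-fluorophenyl would separate the two. On these data alone, how a phenyl group bearing a dimethylamino group or a carboxylic acid would read at this place is also open.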